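This account rests on a few compounds, and the source may have more. Where it says the series, first, only, none or still open, it means among the compounds named here.

Measured so far in a functional assay on HEL cells (Homo sapiens) for cytotoxicity, read by microscopy; on this read-out lower numbers stand for higher toxicity in this test and higher numbers for lower toxicity in this test:
- compound 1, `CCOC(=O)NC(=O)NC1=CS(=O)(=O)O[C@@]12[C@@H](CO[Si](C)(C)C(C)(C)C)O[C@@H](n1cc(C)c(=O)n(C)c1=O)[C@@H]2O[Si](C)(C)C(C)(C)C`, gives 16000 nM
- compound 2, `Cc1cn([C@@H]2O[C@H](CO[Si](C)(C)C(C)(C)C)[C@@]3(OS(=O)(=O)C=C3NC(N)=O)[C@H]2O[Si](C)(C)C(C)(C)C)c(=O)n(C)c1=O`, gives 16000 nM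
- compound 3, `COC(=O)CC(=O)NC1=CS(=O)(=O)O[C@@]12[C@@H](CO[Si](C)(C)C(C)(C)C)O[C@@H](n1cc(C)c(=O)n(C)c1=O)[C@@H]2O[Si](C)(C)C(C)(C)C`, gives 400000 nM

Compound 1 stands level with compound 2, the two together giving the lowest numbers of the three, while compound 3 sits far higher. The step of no change at the digits printed from compound 1 to compound 2 (within the scatter) came with hydrogen in place of ethoxycarbonyl on an amide-type nitrogen. The step of a 25-fold higher number from compound 1 to compound 3 (1.40 log units; beyond the scatter) came with (methoxycarbonyl)methyl in place of (ethoxycarbonyl)amino on a carbonyl carbon.

Compound 4, `C=C(C)C(=O)NC(=O)NC1=CS(=O)(=O)O[C@@]12[C@@H](CO[Si](C)(C)C(C)(C)C)O[C@@H](n1cc(C)c(=O)n(C)c1=O)[C@@H]2O[Si](C)(C)C(C)(C)C`, differs from compound 1 by 1-methylethenyl in place of ethoxy on a carbonyl carbon. The (ethoxycarbonyl)carbamoyl framework is kept as a ((1-methylethenyl)carbonyl)carbamoyl group, so neither measured step tests this exchange directly. Compound 4 is therefore expected to give 16000 nM, between 5000 nM and 60000 nM, a step of no change at the digits printed from compound 1 to compound 4 (within the scatter) that is expected to stay within the scatter.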

Compound 4, minimum cytotoxic concentration: 20000 nM
Beside the measured number, compound 4's estimate is 1.3-fold (0.10 log units) below it, within the range that was stated.
By their numbers in this assay, from the lowest: compounds 1, 2 and 4 (each within the scatter of the next); then compound 3.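

In this assay, the step of a 1.3-fold higher number from compound 1 to compound 4 (0.10 log units; within the scatter) shows that this carbonyl carbon accepts 1-methylethenyl, which holds only carbon, in place of ethoxy while the number stays within the scatter; the step of a 1.3-fold higher number from compound 2 to compound 4 (0.10 log units; within the scatter) likewise stays within it. The step of a 20-fold lower number from compound 3 to compound 4 (1.30 log units; beyond the scatter) is large. Compound 4 thus stands with compound 1 and compound 2, well away from compound 3. No measurement here bears on the reason for these numbers. Still open, as far as these compounds go, is how a longer chain, an amine or a carboxylic acid at this position would read in this assay.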